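A few compounds are considered here, and "the series" means these few. Any claim that something is new, unique, unknown or untested is made for them only; others in the source may bear on it.

Compound 1, `COC(=O)C1=C(C)N=C(C)/C(=C(\O)OC)C1c1ccc(Cl)cc1`, gives 8130 nM in a functional assay (muscle tissue) with Cavia porcellus as the target; a lower number here means that less compound is needed, a higher number that more compound is needed for the effect.
Compound 2, `COC(=O)C1=C(C)N=C(C)/C(=C(\O)OC)C1c1ccccc1Cl`, gives 2.19 nM in this assay.
Compound 3, `COC(=O)C1=C(C)N=C(C)/C(=C(\O)OC)C1c1cccc(Cl)c1Cl`, gives 19.1 nM in this assay.

Among these three, compound 1 stands highest in this assay: the nearest is compound 3, at a 430-fold lower number from compound 1 to compound 3 (2.63 log units; beyond the scatter), and the furthest is compound 2, at a 3700-fold lower number from compound 1 to compound 2 (3.57 log units; beyond the scatter). Compound 4, `COC(=O)C1=C(C)N=C(C)/C(=C(\O)OC)C1c1cccc(N)c1`, is the next member of this series and has not yet been measured. It differs from compound 1 in one place: 3-aminophenyl in place of 4-chlorophenyl on a saturated ring carbon.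

Among the compounds with values here, two measured steps bear on this change, since both also replace the 4-chlorophenyl of compound 1 with a differently substituted phenyl. Both were large and in the same direction, namely a 3700-fold lower number from compound 1 to compound 2 (3.57 log units; beyond the scatter) and a 430-fold lower number from compound 1 to compound 3 (2.63 log units; beyond the scatter). The step of an 8.7-fold higher number from compound 2 to compound 3 (0.94 log units; beyond the scatter), by contrast, shows that adding chloro where a 2-chlorophenyl already sits moves the number modestly upward. Within the data shown here, no measured compound carries an amino group, so the 3-aminophenyl itself has no precedent here. On the strength of the two departures from 4-chlorophenyl, compound 4 is expected to show a lower number than compound 1, with the step estimated at a 27-fold lower number from compound 1 to compound 4 (1.43 log units; beyond the scatter). The estimate for compound 4 in this assay is 300 nM, within a range from 20 nM to 4000 nM.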

Compound 4, half-maximal effective concentration: 2000 nM
Compound 4: middle estimate off by 6.7-fold (0.82 log units), on the low side; low and high end bracket the measured number.
By their numbers in this assay, from the lowest: compound 2; then compound 3; then compound 4; then compound 1.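

Within the data shown here, the step of a 4.1-fold lower number from compound 1 to compound 4 (0.61 log units; beyond the scatter) is the first departure from 4-chlorophenyl at this saturated ring carbon that brings only a modest change, so the large drops seen earlier do not follow from every such replacement. The 3-aminophenyl of compound 4 also sits far from the two chlorinated groups with the lowest numbers, with a 100-fold higher number from compound 3 to compound 4 (2.02 log units; beyond the scatter) and a 910-fold higher number from compound 2 to compound 4 (2.96 log units; beyond the scatter) both large. Among the four compounds, the low numbers therefore belong only to the 2-chlorophenyl and 2,3-dichlorophenyl groups, while the 4-chlorophenyl and 3-aminophenyl groups both stay well above them, and no evidence at hand accounts for this difference.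

Going by these compounds, what a 3-chlorophenyl or a 2-aminophenyl would give at this carbon remains open, and with it whether the distance of compound 4 from compound 2 follows from the amino group itself or from where the substituent stands on the phenyl ring. Also open, on these data alone, is whether a nitro or a methoxy group on the same phenyl ring would bring the number down to the level of the chlorinated compounds or leave it near that of compound 4.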